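Fluorine for Chlorine on the Aryl Ring of Compound 1

This account rests on a few compounds, and the source may have more. Where it says the series, first, only, none or still open, it means among the compounds named here.

Three compounds have been measured in an assay for inhibition of leukotriene C4 synthase (Homo sapiens), read by LC-MS, with stated times of 15 min and 30 min; a lower number here means a stronger inhibitor, a higher number a weaker inhibitor:

compound 1, `COc1cc(N(CC2CC2)c2ccc(Cl)c(Cl)c2)cnc1C(=O)[C@H]1C[C@@H]1C(=O)O`: 4.94 nM
compound 2, `COc1cc(N(CC(C)C)c2cccc(C(F)(F)F)c2)cnc1C(=O)[C@H]1C[C@@H]1C(=O)O`: 4.74 nM
compound 3, `COc1cc(N(CC(C)(C)O)c2cccc(C(F)(F)F)c2)cnc1C(=O)[C@H]1C[C@@H]1C(=O)O`: 31.8 nM

Compound 1 stands second highest of the three. Its nearest neighbour is compound 2, whose value lies within the scatter of that of compound 1, so no order between the two can be read. Compound 3 lies furthest away, beyond the scatter, with the weaker number.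

The unmeasured compound is compound 4, `COc1cc(N(CC2CC2)c2ccc(F)c(Cl)c2)cnc1C(=O)[C@H]1C[C@@H]1C(=O)O`. It differs from compound 1 by fluoro in place of chloro on an aromatic carbon; cut one bond further out, the change reads 3,4-dichlorophenyl to 3-chloro-4-fluorophenyl.

Within the data shown here, only one step is available among the measured pairs, a 6.7-fold higher number from compound 2 to compound 3 (0.83 log units; beyond the scatter), and it concerns the chain on the nitrogen, not the aromatic ring. Among the measured compounds shown here, no measured step bears on a halogen swap on the aryl ring. With nothing pointing either way, the account therefore expects a step from compound 1 to compound 4 of a 1.4-fold higher number from compound 1 to compound 4 (0.15 log units; within the scatter), that is, no change beyond the scatter, with a slight lean toward a higher number.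

For compound 4 in this assay the estimated value is 7 nM, with a range from 2.5 nM to 20 nM.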

Compound 4, half-maximal inhibitory concentration: 5.26 nM
For compound 4 the middle estimate is 1.3-fold (0.12 log units) above the measured one, and the stated range covers the measured number.
By their numbers in this assay, from the lowest: compounds 2, 1 and 4 (each within the scatter of the next); then compound 3.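

In this assay, fluoro in place of chloro on this aromatic carbon, para to a large group and ortho to a chloro group, gives a 1.1-fold higher number from compound 1 to compound 4 (0.03 log units; within the scatter), so no order between the two compounds can be read. Among these compounds, the one earlier step concerned the chain on the nitrogen, whereas this step is the first on the aryl ring, and it shows that 3,4-dichlorophenyl and 3-chloro-4-fluorophenyl are not told apart by this measurement when the rest of compound 1 stays the same. Nothing available bears on why these two halogens read alike here.

The compounds shown leave open how this aromatic carbon would respond to something other than these two halogens, such as bromo, an amine or a carboxylic acid, or to plain hydrogen. They also leave open whether the same swap would read alike with a different chain on the nitrogen, such as the hydroxy-bearing chain of compound 3.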